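Aryl ether series: from pyridazinyl ethoxy to methoxy

The source may hold more compounds than are shown below. What is called first, only, known or untested is meant among the compounds shown, and "the series" means these compounds.

Measured compounds in an assay for inhibition of kynurenine 3-monooxygenase (Homo sapiens), read by mass spectrometry, with a stated time of 1 h; on this read-out higher numbers stand for weaker inhibition and lower numbers for stronger inhibition:
compound 1 `O=C(O)CCn1c(=O)oc2cc(OCC3CCC3)c(Cl)cc21` — 25.1 nM
compound 2 `CCc1cc2oc(=O)n(CCC(=O)O)c2cc1Cl` — 10 nM
compound 3 `C[C@@H](Oc1cc2oc(=O)n(CCC(=O)O)c2cc1Cl)c1cccnn1` — 1.26 nM

Compound 3 stands lowest of the three numbers in this assay; compound 2 gives 10 nM and compound 1 gives 25.1 nM, both beyond the scatter from compound 3. The two measured steps both start from compound 1: a 2.5-fold lower number from compound 1 to compound 2 (0.40 log units; beyond the scatter), and a 20-fold lower number from compound 1 to compound 3 (1.30 log units; beyond the scatter).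

Compound 4 `COc1cc2oc(=O)n(CCC(=O)O)c2cc1Cl` is not yet measured in this assay. It differs from compound 3 by one carbon atom in place of a group of 8 heavy atoms (6 carbon, 2 nitrogen; one six-membered aromatic ring with 2 hetero atoms), on an oxygen on an aromatic ring. For the measured compounds named here, the step that bears most directly on this change is the one from compound 1 to compound 3, where the aromatic group on the ether oxygen brought the large lowering; compound 4 strips that group back to a single carbon, smaller even than the cyclobutylmethyl of compound 1. The step from compound 1 to compound 2 shows that a small carbon substituent at this position also sits modestly below compound 1. The expectation is therefore a large step upward from compound 3, landing near or somewhat above compound 1 and compound 2.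

Compound 4 is estimated at 40 nM, with a range of 10 nM to 160 nM, which means an expected step of a 32-fold higher number from compound 3 to compound 4 (1.50 log units; beyond the scatter).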

Compound 4, half-maximal inhibitory concentration: 12.6 nM
The estimate for compound 4 lay 3.2-fold (0.50 log units) above the measured number, within the range that was stated.
By their numbers in this assay, from the lowest: compound 3; then compounds 2, 4 and 1 (each within the scatter of the next, the first and the last beyond it).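

In this assay, replacing the group of 8 heavy atoms on the ether oxygen with methyl gives a 10-fold higher number from compound 3 to compound 4 (1.00 log units; beyond the scatter) and so ties the low number of compound 3 to that larger group, not to the ether oxygen alone. Without that group, size matters little here: methoxy against ethyl on the aromatic carbon gives a 1.3-fold higher number from compound 2 to compound 4 (0.10 log units; within the scatter) and loss of the cyclobutyl gives a 2.0-fold lower number from compound 1 to compound 4 (0.30 log units; within the scatter) even though compound 1 and compound 2 themselves stand apart, with a 2.5-fold lower number from compound 1 to compound 2 (0.40 log units; beyond the scatter) as their step. Nothing measured here accounts for what the group of 8 heavy atoms adds.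

Still open, from the compounds shown here alone, is which part of that group carries the step: a phenyl ring in place of the six-membered aromatic ring with 2 hetero atoms, the same ring without the branching methyl, or the opposite configuration at the defined stereocentre could each separate these features. The compounds shown also say nothing of how an amine or a longer chain ending in a carboxylic acid on the same oxygen would compare with the methyl ether.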